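Swapping an Acyl Aryl for an Arylamino on a Carbonyl

The source may report more compounds than this note shows. Statements on the series, on what has been measured and on what is new or still open speak of the compounds shown alone.

Compound 1 `COc1cc(-c2nn(-c3cccc(NC(=O)c4cccc(C(F)(F)F)c4)c3)cc2-c2ccncc2)ccc1Cl` is the starting point. In a functional assay on NCI-H23 cells (Homo sapiens) for inhibition, read by sulforhodamine B assay, with a stated time of 48 h (on this read-out higher numbers stand for weaker inhibition of growth and lower numbers for stronger inhibition of growth), compound 1 gives 32500 nM, the highest of the three numbers in hand, so among these three it is the weakest inhibitor of growth. The two other measured compounds carry an aminoaryl on the carbonyl and a hydroxy in place of the methoxy on the shared core. Compound 2 `O=C(Nc1cccc(-n2cc(-c3ccncc3)c(-c3ccc(Cl)c(O)c3)n2)c1)Nc1cc(C(F)(F)F)cc(C(F)(F)F)c1` gives 3270 nM in this assay, and compound 3 `O=C(Nc1cccc(-n2cc(-c3ccncc3)c(-c3ccc(Cl)c(O)c3)n2)c1)Nc1ccc(Cl)c(C(F)(F)F)c1` gives 3330 nM; these two lie within the usual scatter of each other, and both sit well beyond the scatter from compound 1.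

Compound 4 `COc1cc(-c2nn(-c3cccc(NC(=O)Nc4ccc(Cl)c(Cl)c4)c3)cc2-c2ccncc2)ccc1Cl` has not yet been measured. It differs from compound 1 in one place: (3,4-dichlorophenyl)amino in place of 3-(trifluoromethyl)phenyl on a carbonyl carbon. Cut one bond further out, the change reads (3-(trifluoromethyl)phenyl)carbonyl to (3,4-dichlorophenyl)carbamoyl, so compound 4 carries the same arylamino-on-carbonyl arrangement as compounds 2 and 3 while keeping the methoxy of compound 1. Among the compounds with values here, no measured pair isolates this single change; compounds 2 and 3 differ from compound 1 in two places at once. Still, the gap between compound 1 at 32500 nM and the two others points downward. The step of a 4.1-fold lower number from compound 1 to compound 4 (0.61 log units; beyond the scatter) is expected to be a clear drop, somewhat smaller than that gap. Compound 4 is estimated at 8000 nM, within 2500 nM to 25000 nM.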

Compound 4, concentration for total growth inhibition: 5190 nM
For compound 4 the middle estimate is 1.5-fold (0.19 log units) above the measured one; measured number inside the range.
By their numbers in this assay, from the lowest: compounds 2, 3 and 4 (each within the scatter of the next); then compound 1.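

With the methoxy of compound 1 kept in place, putting (3,4-dichlorophenyl)amino in place of 3-(trifluoromethyl)phenyl on this carbonyl carbon gives a 6.3-fold lower number from compound 1 to compound 4 (0.80 log units; beyond the scatter) in this assay, so a change at this one position is enough to strengthen growth inhibition. Compounds 2 and 3 could not show this, since each differs from compound 1 in two places at once, leaving the carbonyl change tangled with the swap of methoxy for hydroxy. No measurement at hand explains why this single change lowers the number.

This one step also alters two things together, the added amino nitrogen and the substituents on the aromatic ring, so the compounds shown do not tell which of the two carries the drop, and a 3-(trifluoromethyl)phenylamino group on the same carbonyl carbon would pull them apart. Also open, on these data alone, is how far the position tolerates something other than an aromatic ring, such as a morpholine or a cyclohexylamino group on this carbonyl carbon.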